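The source may report more compounds than this note shows. Statements on the series, on what has been measured and on what is new or still open speak of the compounds shown alone.

In a functional assay on CCRF-CEM cells (Homo sapiens) for inhibition, read by MTT assay, with a stated time of 72 h (on this read-out higher numbers stand for weaker inhibition and lower numbers for stronger inhibition), compound 1 `COc1cc(NC(C)CCCNC(=O)Nc2ccc(Br)cc2)c2ncccc2c1` gives 23000 nM while compound 2 `COc1cc(NC(C)CCCNC(=O)Nc2cc(C(F)(F)F)cc(C(F)(F)F)c2)c2ncccc2c1` gives 4100 nM and compound 3 `COc1cc(NC(C)CCCNC(=O)Nc2ccc(C(F)(F)F)cc2)c2ncccc2c1` gives 14000 nM on the shared core. Compound 3 thus lies within the scatter of compound 1, and its number is higher than that of compound 2 by more than the scatter. Compound 4 `COc1cc(NC(C)CCCNC(=O)Nc2cccc(C(F)(F)F)c2)c2ncccc2c1` differs from compound 3 by 3-(trifluoromethyl)phenyl in place of 4-(trifluoromethyl)phenyl on an amide-type nitrogen. Among the measured compounds shown here, the only measured step (a 1.6-fold lower number from compound 1 to compound 3 (0.22 log units; within the scatter)) is trifluoromethyl in place of bromo and lies within the scatter. For the measured compounds named here, no measured pair shows this change itself, so no step beyond the scatter is expected in this assay here. The estimated step is small (a 1.3-fold lower number from compound 3 to compound 4 (0.10 log units; within the scatter)). For compound 4 the expected value is 11000 nM (estimated range 5500 nM to 22000 nM).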

Compound 4, half-maximal inhibitory concentration: 19000 nM
Compound 4: middle estimate off by 1.7-fold (0.24 log units), on the low side; low and high end bracket the measured number.
By their numbers in this assay, from the lowest: compound 2; then compounds 3, 4 and 1 (each within the scatter of the next).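

In this assay, 3-(trifluoromethyl)phenyl in place of 4-(trifluoromethyl)phenyl on the amide-type nitrogen gives a 1.4-fold higher number from compound 3 to compound 4 (0.13 log units; within the scatter), and 3-(trifluoromethyl)phenyl in place of 4-bromophenyl gives a 1.2-fold lower number from compound 1 to compound 4 (0.08 log units; within the scatter), so neither exchange at this position separates the compounds. Hydrogen in place of one trifluoromethyl is the change that does register, with a 4.6-fold higher number from compound 2 to compound 4 (0.67 log units; beyond the scatter). No supporting measurement bears on the reason for this result. The compounds shown leave open how a nitrile, a methoxy group or an amine on this ring would read, and whether a urea-free linker or a longer chain would matter.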